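A few compounds are considered here, and "the series" means these few. Any claim that something is new, unique, unknown or untested is made for them only; others in the source may bear on it.

Working notes on a small set sharing the core of compound 1 `CCOC(=O)C1=C(Nc2ccccc2)S/C(=C\c2ccc(Br)c(O)c2)C1=O`. In a functional assay on A549 cells (Homo sapiens) for inhibition, read by MTT assay, with a stated time of 72 h, tested at 10 uM (a higher number here means more inhibition at the concentration tested (going by the name of the read-out), a lower number less inhibition), compound 1 gives 13.6%. Compound 2 `CCOC(=O)C1=C(Nc2ccccc2)S/C(=C\c2ccc[nH]2)C1=O` carries 1H-pyrrol-2-yl in place of 4-bromo-3-hydroxyphenyl on the double-bonded chain carbon; in this assay compound 2 gives 23.5%. That number is the highest of the three, but both other numbers lie within the scatter of it, so no order among the three is claimed. The step of a number 9.9 percentage points higher from compound 1 to compound 2 (within the scatter) is within the scatter. Compound 3 `CCOC(=O)C1=C(Nc2cccc(C(F)(F)F)c2)S/C(=C\c2ccc[nH]2)C1=O` has trifluoromethyl in place of hydrogen on an aromatic carbon of the anilino ring; in this assay compound 3 gives 22.8%, and a number 0.7 percentage points lower from compound 2 to compound 3 (within the scatter) is within the scatter.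

Compound 4 `CCOC(=O)C1=C(Nc2ccc(C)cc2)S/C(=C\c2ccc[nH]2)C1=O` differs from compound 2 by methyl in place of hydrogen on an aromatic carbon. The measured step that bears on it is the substituent change on the same anilino ring, a number 0.7 percentage points lower from compound 2 to compound 3 (within the scatter), which stayed within the scatter; the step of a number 9.9 percentage points higher from compound 1 to compound 2 (within the scatter) concerns another part of the molecule and is not taken as a guide. No step beyond the scatter is therefore expected in this assay, and the expected step is a number 0.5 percentage points lower from compound 2 to compound 4 (within the scatter). Compound 4 is estimated to give 23%, within a range from 11% to 35%.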

Compound 4, a percentage reported as inhibition, at one concentration (the size of the read-out at that concentration, not a potency): 20.9%
For compound 4 the middle estimate is 2.1 percentage points above the measured one; low and high end bracket the measured number.
By their numbers in this assay, from the lowest: compounds 1, 4, 3 and 2 (each within the scatter of the next).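

In this assay, a number 2.6 percentage points lower from compound 2 to compound 4 (within the scatter) shows that phenyl can become 4-methylphenyl, with a single carbon added para to a large group, without a step beyond the scatter. Until now, the only substituent on the anilino ring was trifluoromethyl, with a number 0.7 percentage points lower from compound 2 to compound 3 (within the scatter), so two different groups on this ring, each compared with compound 2 in a single place, now give steps within the scatter. Nothing at hand bears on the cause of this result.

On these data alone, whether an amine, a carboxylic acid or a longer chain such as n-butyl on the anilino ring would give a step beyond the scatter remains open, as does the effect of a methyl at any other carbon of that ring. Also open, as far as these compounds go, is whether the same steps stay within the scatter on the shared core when the pyrrol-2-yl group is replaced, and whether a reading at one concentration reflects how these compounds would compare across a range of concentrations.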